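Thiazolidine propiolamides: aryl for alkyl at the ring carbon

This account rests on a few compounds, and the source may have more. Where it says the series, first, only, none or still open, it means among the compounds named here.

Three compounds of the series have numbers in a functional assay on Huh-7 cells (Homo sapiens) for inhibition, read by sulforhodamine B assay; a higher number here means a weaker inhibitor, a lower number a stronger inhibitor. Compound 1 `C#CC(=O)N1C(C(C)CCC)SC[C@@H]1C(=O)OCC` gives 600 nM in this assay, compound 2 `C#CC(=O)N1C(c2ccccc2)SC[C@@H]1C(=O)OCC` gives 5300 nM, and compound 3 `C#CC(=O)N1C(CCCCC)SC[C@@H]1C(=O)OCC` gives 1800 nM. Compound 3 therefore stands second highest of the three numbers: its nearest neighbour is compound 2, and the step of a 2.9-fold lower number from compound 2 to compound 3 (0.47 log units; beyond the scatter) lies beyond the scatter, while toward compound 1 the step of a 3.0-fold higher number from compound 1 to compound 3 (0.48 log units; beyond the scatter) is also beyond the scatter.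

Compound 4 `C#CC(=O)N1C(c2ccccc2F)SC[C@@H]1C(=O)OCC` is the next case, differing from compound 3 only in this way: 2-fluorophenyl in place of pentyl on a saturated ring carbon. The step that bears most directly on it is the reverse of a 2.9-fold lower number from compound 2 to compound 3 (0.47 log units; beyond the scatter), which says that phenyl on the same ring carbon gives a modestly higher number than pentyl. The step of an 8.8-fold higher number from compound 1 to compound 2 (0.95 log units; beyond the scatter) points the same way, with an aromatic group on that carbon again giving the higher number. For the measured compounds named here, no measured compound carries a fluorine, so the effect of 2-fluorophenyl as against phenyl has no precedent here.

On this basis compound 4 is expected to give a modestly higher number than compound 3, a step of about a 2.8-fold higher number from compound 3 to compound 4 (0.44 log units; beyond the scatter), landing near compound 2. The estimate for compound 4 in this assay is 5000 nM, with a range of 1500 nM to 15000 nM.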

Compound 4, half-maximal inhibitory concentration: 1700 nM
Compound 4: the middle estimate sits 2.9-fold (0.47 log units) above what was measured; measured number inside the range.
By their numbers in this assay, from the lowest: compound 1; then compounds 4 and 3 (each within the scatter of the next); then compound 2.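

In this assay, the earlier link between an aromatic group on this saturated ring carbon and a higher number does not hold for every aromatic group: with 2-fluorophenyl in place of pentyl, a 1.1-fold lower number from compound 3 to compound 4 (0.02 log units; within the scatter) leaves the two groups not told apart. The aromatic group itself can therefore change the number at this position, as fluoro in place of hydrogen on an aromatic carbon gives a 3.1-fold lower number from compound 2 to compound 4 (0.49 log units; beyond the scatter), a modest step and the first in the series made on the aromatic ring rather than at the ring carbon. The 1-methylbutyl group of compound 1 still gives the lowest number, with a 2.8-fold higher number from compound 1 to compound 4 (0.45 log units; beyond the scatter), and nothing available accounts for the fluoro step or for this order.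

Going by these compounds, whether chloro or methoxy in place of the fluoro would give a step of similar size remains open. On these data alone, it is also open whether cyclohexyl or another branched alkyl group on the same ring carbon would match 1-methylbutyl, or whether that low number belongs to this one group alone.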